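The compounds below may be only part of what the source reports. "The series", "measured", "known", "first", "only" and "open" are said of these compounds alone.

Compound 1 `O=C(O)CCC[C@H]1CC[C@@H]2[C@@H](/C=C/[C@@H](O)COc3ccccc3)[C@H](O)C[C@@H]2O1` gives 3.6 nM in a functional assay on CHO cells for agonist activity at prostaglandin E2 receptor EP3 subtype (Homo sapiens), read by fluorescence and calcium flux; a lower number here means that less compound is needed, a higher number that more compound is needed for the effect. Two ring-opened relatives differ sharply: compound 2 `O=C(O)CCC1=CC[C@@H]2[C@@H](/C=C/[C@@H](O)COc3ccccc3)[C@H](O)C[C@@H]2OC1` gives 2700 nM, and compound 3 `O=C(O)CCCC1=CC[C@@H]2[C@@H](/C=C/[C@@H](O)COc3ccccc3)[C@H](O)C[C@@H]2OC1` gives 4700 nM. Compound 3 thus sits at the weak end of the three numbers, far from compound 1, while its distance from compound 2 is a 1.7-fold higher number from compound 2 to compound 3 (0.24 log units; within the scatter), which is within the scatter. Compound 4 `O=C(O)CCCCC1=CC[C@@H]2[C@@H](/C=C/[C@@H](O)COc3ccccc3)[C@H](O)C[C@@H]2OC1` continues in the same manner: carboxymethyl in place of carboxy on a saturated chain carbon, three bonds along the chain from a double-bonded ring carbon. Among the compounds with values here, the only step that bears on this change is the one from compound 2 to compound 3, a lengthening of the same acid chain by one carbon, and it stayed within the scatter. The step from compound 3 to compound 4 is therefore expected to be a 1.3-fold higher number from compound 3 to compound 4 (0.11 log units; within the scatter), no more than scatter. Compound 4 is estimated to give 6000 nM, within a range of 2500 nM to 15000 nM.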

Compound 4, half-maximal effective concentration: 13 nM
Compound 4: middle estimate off by 460-fold (2.66 log units), on the high side; measured number outside the range, below it.
By their numbers in this assay, from the lowest: compound 1; then compound 4; then compounds 2 and 3 (each within the scatter of the next).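

Lengthening the acid chain at this saturated chain carbon does not act evenly. In this assay the last added carbon gives a 360-fold lower number from compound 3 to compound 4 (2.56 log units; beyond the scatter), although the previous lengthening gave only a 1.7-fold higher number from compound 2 to compound 3 (0.24 log units; within the scatter), which lies within the scatter. Measured across both additions, the change gives a 210-fold lower number from compound 2 to compound 4 (2.32 log units; beyond the scatter), so among these three compounds the sharp fall in the number appears only with 4-carboxybutyl. No measurement available here accounts for this jump. On these data alone, whether a still longer chain, such as 5-carboxypentyl, keeps the low number remains open, as does whether an amide could replace the carboxylic acid at the chain end.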